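Fluoro to trifluoromethyl on a cytotoxicity read-out

The source may hold more compounds than are shown below. What is called first, only, known or untested is meant among the compounds shown, and "the series" means these compounds.

Compound 1 `COc1ccc(S(=O)(=O)n2c(-c3cn(-c4ccccc4)nc3-c3ccc(F)cc3)nc3ccccc32)cc1`: 37300 nM
Compound 2 `O=[N+]([O-])c1ccc(S(=O)(=O)n2c(-c3cn(-c4ccccc4)nc3-c3ccc(F)cc3)nc3ccccc32)cc1`: 189000 nM

In an ADME assay on HEK-293T cells (Homo sapiens) for cytotoxicity, read by MTT assay, with a stated time of 24 h (on this read-out lower numbers stand for higher toxicity in this test and higher numbers for lower toxicity in this test), compound 1 stands lowest of the two measured compounds at 37300 nM. Compound 3 `COc1ccc(S(=O)(=O)n2c(-c3cn(-c4ccccc4)nc3-c3ccc(C(F)(F)F)cc3)nc3ccccc32)cc1` keeps the core of compound 1 and changes one group: trifluoromethyl in place of fluoro on an aromatic carbon. For the measured compounds named here, the only measured step, a 5.1-fold higher number from compound 1 to compound 2 (0.70 log units; beyond the scatter), replaces methoxy with nitro at a different place, so it bears on this change only loosely. Going by the values given here, no measured step tests this change directly, and no shift beyond the scatter is expected in this assay. The expected step is a 1.1-fold higher number from compound 1 to compound 3 (0.03 log units; within the scatter). For compound 3 the estimated value is 40000 nM, with an expected range of 15000 nM to 110000 nM.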

Compound 3, half-maximal cytotoxic concentration: > 300000 nM
Compound 3 gave a limit, no number; the forecaster's own chance of this, stated with the estimate: 5%; at least 7.5-fold (0.87 log units) between middle value and limit.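

In this assay, the change from 4-fluorophenyl to 4-(trifluoromethyl)phenyl gives an at least 8.0-fold higher number from compound 1 to compound 3 (0.90 log units; beyond the scatter). This shows that the read-out responds to a change at this position, para to a large group, which the step from methoxy to nitro at a different place could not show. Compound 3 gives a limit and not a number, so the full size of the step stays unknown: the limit of > 300000 nM in this assay, at which 1 of the 3 values shown sits.

The compounds shown leave open whether chloro, methyl or an amine at this position would shift the read-out likewise. They also leave open whether trifluoromethyl would act the same way alongside nitro, as in compound 2.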